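Swapping the Aryl Amine Cap on a Shared Core

A few compounds are considered here, and "the series" means these few. Any claim that something is new, unique, unknown or untested is made for them only; others in the source may bear on it.

Measured so far:
compound 1 `FC(F)(F)c1ccc(Nc2nccc(-c3cnc4ccccc4c3)n2)cc1`: 24%
compound 2 `Cc1ccc(Nc2nccc(-c3c(C)nc4ccccn34)n2)cc1`: 95.2%

Of the compounds shown here, two have been measured in a functional assay on HCT-15 cells (Homo sapiens) for cytotoxicity, read by sulforhodamine B assay, with a stated time of 48 h, tested at 50 uM; a higher number here means more inhibition at the concentration tested (going by the name of the read-out), a lower number less inhibition. Compound 1 `FC(F)(F)c1ccc(Nc2nccc(-c3cnc4ccccc4c3)n2)cc1` gives 24% in this assay. Compound 2 `Cc1ccc(Nc2nccc(-c3c(C)nc4ccccn34)n2)cc1` gives 95.2% in this assay. Within the data shown here, compound 2 stands highest of the two numbers; the only other number, that of compound 1, lies far lower, beyond the scatter. The two compounds differ in more than one place, however, so their gap cannot be assigned to any single change.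

Compound 3 `Cc1nc2ccccn2c1-c1ccnc(Nc2ccc(C=O)s2)n1` has not yet been measured. It differs from compound 2 in one place: 5-formylthiophen-2-yl in place of 4-methylphenyl on a nitrogen on an aromatic ring. Among the measured compounds shown here, no measured pair shows this change, so the size of the step is not known from the data. Compound 2 already gives 95.2%, which leaves little room upward. On these data alone, the step from compound 2 to compound 3 in this assay is expected to be a number 25.2 percentage points lower from compound 2 to compound 3 (beyond the scatter), downward, and whether it lies beyond the scatter remains open. Compound 3 is expected to give 70% in this assay, with a range from 30% to 97%.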

Compound 3, a percentage reported as inhibition, at one concentration (the size of the read-out at that concentration, not a potency): 85.4%
For compound 3 the middle estimate is 15.4 percentage points below the measured one; low and high end bracket the measured number.
By their numbers in this assay, from the lowest: compound 1; then compounds 3 and 2 (each within the scatter of the next).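

In this assay, among these compounds, putting 5-formylthiophen-2-yl in place of 4-methylphenyl on the nitrogen gives the first step in this set that can be read at a single place, and it comes to a number 9.8 percentage points lower from compound 2 to compound 3 (within the scatter). At this one concentration, then, the two groups cannot be told apart, even though a six-membered aromatic ring of carbon only gives way to a five-membered aromatic ring with one hetero atom, and a group without hydrogen-bond acceptors gives way to one that has them. Nothing measured here explains this outcome, and the read-out gives the size of inhibition at that concentration and not a potency.

The compounds shown leave open whether the formyl group contributes at all, since neither an unsubstituted thiophene nor a thiophene carrying a carboxylic acid or an aminomethyl group in its place appears among them. The large gap between compound 1 and the other two compounds also remains unassigned, as compound 1 differs from each of them in more than one place.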